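Chloro for Fluoro on a Benzylthio Thiadiazole and Triazole Pair

This account rests on a few compounds, and the source may have more. Where it says the series, first, only, none or still open, it means among the compounds named here.

Compound 1, `Fc1ccc(CSc2nnc(-c3cnccn3)s2)cc1`: in a functional assay on HeLa cells (Homo sapiens) for antiproliferative activity, read by MTT assay, with a stated time of 48 h (a higher number here means a weaker inhibitor, a lower number a stronger inhibitor), compound 1 gives > 50000 nM, which is a limit of the assay and not a number.
Compound 2, `Clc1ccc(CSc2nnc(-c3cnccn3)s2)cc1`: in this assay compound 2 gives 18900 nM.
Compound 3, `Fc1ccc(CSc2nnc(-c3cnccn3)n2-c2ccccc2)cc1`: in this assay compound 3 gives 7300 nM.

Within the data shown here, the one measured step joins compound 1 and compound 2, which share a core and differ only by chloro in place of fluoro on an aromatic carbon. That step, an at least 2.6-fold lower number from compound 1 to compound 2 (0.42 log units; beyond the scatter), can only be given as a lower bound because of the limit of > 50000 nM in this assay, at which 1 of the 3 values shown sits. Compound 3 carries a different core; how that core differs from the core of compound 1 is not broken down here. Its value stands as the lowest of the two numbers given, and compound 2 sits at a higher number than compound 3.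

Compound 4, `Clc1ccc(CSc2nnc(-c3cnccn3)n2-c2ccccc2)cc1`, has not yet been measured in this assay. It stands to compound 3 as compound 2 stands to compound 1: the difference is chloro in place of fluoro on an aromatic carbon, at the same place, so it is the same change. Because compound 1 to compound 2 gave an at least 2.6-fold lower number from compound 1 to compound 2 (0.42 log units; beyond the scatter) and is itself only a bound, the step from compound 3 to compound 4 is expected to be of similar or somewhat smaller size, a 2.3-fold lower number from compound 3 to compound 4 (0.36 log units; beyond the scatter). On that basis compound 4 is estimated to give about 3200 nM in this assay, most likely between 1200 nM and 8000 nM.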

Compound 4, half-maximal inhibitory concentration: > 50000 nM
Compound 4 was reported as a limit; the forecaster's own chance of this, stated with the estimate: 2%; middle value at least 15-fold (1.19 log units) from the limit.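

Chloro in place of fluoro gives an at least 6.8-fold higher number from compound 3 to compound 4 (0.83 log units; beyond the scatter) in this assay, so on the core of compound 3 the change runs in the opposite direction to its effect on the core of compound 1, and the two steps clearly differ: the same change on two cores in this assay, an at least 2.6-fold lower number (0.42 log units; beyond the scatter) from compound 1 to compound 2 and an at least 6.8-fold higher number (0.83 log units; beyond the scatter) from compound 3 to compound 4, at least 18-fold (1.25 log units) apart, beyond the scatter of two such steps. Neither step has an exact size, since each has a limit of the assay at one end and can be read only as a bound: the limit of > 50000 nM in this assay, at which 2 of the 4 values shown sit. The change therefore did not carry from one core to the other in this series, but a single pair on each core shows only that its direction reversed, not how large either step truly is, why the cores behave differently, or whether the same would hold on any further core.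

The compounds shown leave open how other groups at the same place on the aromatic ring, such as bromo, methoxy or an amine, would behave on these two cores. They also leave open whether a longer chain in place of the 4-fluorobenzyl or 4-chlorobenzyl group would show the same reversal between the cores.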